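The compounds below may be only part of what the source reports. "The series", "measured", "known", "first", "only" and "open" are said of these compounds alone.

Among the measured compounds shown here, in a functional assay for agonist activity at G protein-coupled receptor 88 (Homo sapiens), read by HTRF and cAMP accumulation (a higher number here means that more compound is needed for the effect, a lower number that less compound is needed), only two compounds have been measured, and only one of them gives a number. Compound 1, with structure `CC(C)CCCN(C(=O)[C@@H]1C[C@H]1c1ccccc1)c1ccc(-c2ccccc2)cc1`, gives > 100 nM, which is a limit of the assay rather than a measured number. Compound 2, with structure `CC[C@H](C)[C@H](N)CN(C(=O)[C@@H]1C[C@H]1c1cccc(Cl)c1)c1ccc(-c2ccccc2)cc1`, gives 2200 nM in this assay; this is the only actual number shown, and it therefore sets the only point from which an expectation can be built. Compound 3, with structure `CC[C@H](C)[C@H](N)CN(C(=O)[C@@H]1C[C@H]1c1ccccc1F)c1ccc(-c2ccccc2)cc1`, has not yet been measured. It differs from compound 2 in one place: 2-fluorophenyl in place of 3-chlorophenyl on a saturated ring carbon. The aryl group on the saturated ring carbon changes, while the shared core and the rest of the molecule stay the same. For the measured compounds named here, no measured step of this kind exists here, so the size and direction of the effect are open. A change from one halogen-bearing phenyl ring to another is, as a rule, expected to shift potency only modestly, and the estimate is for the value of compound 3 to stay within the usual scatter of compound 2, a step of a 1.4-fold higher number from compound 2 to compound 3 (0.13 log units; within the scatter). Compound 3 is expected to give about 3000 nM in this assay, with a likely range from 1000 nM to 9000 nM.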

Compound 3, half-maximal effective concentration: 650 nM
For compound 3 the middle estimate is 4.6-fold (0.66 log units) above the measured one; the whole stated range lies above it.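

The step shows that the aryl group on the three-membered ring is not a silent position in this assay: the change to 2-fluorophenyl gives a 3.4-fold lower number from compound 2 to compound 3 (0.53 log units; beyond the scatter) and so less compound is needed for the effect. Before this result no step at this position could be read, and now one swap between two halogen-bearing phenyl rings of the same size, with the shared core and the rest of the molecule unchanged, is seen to move the value beyond the usual scatter of repeated measurements. Nothing measured here accounts for the size or the direction of this step.

Two things change together in this single step, the halogen, chlorine giving way to fluorine, and the place it holds on the phenyl ring, so the step cannot be credited to either one alone; a 2-chlorophenyl or a 3-fluorophenyl group on the same ring carbon would pull the two apart. As far as these compounds go, it also remains open how far this position can be pushed, for instance with a 2-methoxyphenyl group or a 2,6-difluorophenyl group.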